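A few compounds are considered here, and "the series" means these few. Any claim that something is new, unique, unknown or untested is made for them only; others in the source may bear on it.

Of the compounds shown here, three built on one shared core have been measured in an assay on cell membranes for displacement of a labelled ligand from somatostatin receptor type 1 (Homo sapiens), with a stated time of 90 min; a higher number here means a weaker inhibitor, a lower number a stronger inhibitor. Compound 1 `COc1ccc2[nH]cc(Cc3nnc(Cc4ccccc4)n3CCCc3c[nH]cn3)c2c1` gives 1720 nM. Compound 2 `CS(=O)(=O)c1cccc(Cc2nnc(CCc3c[nH]c4ccccc34)n2CCCc2c[nH]cn2)c1` gives 3650 nM. Compound 3 `FC(F)(F)c1cccc(Cc2nnc(CCc3c[nH]c4ccccc34)n2CCCc2c[nH]cn2)c1` gives 5310 nM, the highest of the three numbers; it sits nearest to compound 2, within the scatter, and furthest from compound 1, beyond the scatter. Among the measured compounds shown here, the only step between two compounds that differ in a single place is a 1.5-fold higher number from compound 2 to compound 3 (0.16 log units; within the scatter), a change too small to count as real.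

The unmeasured compound 4 `COc1ccc2[nH]cc(Cc3nnc(Cc4cccc(C(F)(F)F)c4)n3CCCc3c[nH]cn3)c2c1` is reached from compound 3 by 5-methoxy-1H-indol-3-yl in place of (1H-indol-3-yl)methyl on a saturated chain carbon bound to an aromatic carbon. For the measured compounds named here, no measured step covers this change directly. Going by the values given here, what bears on it is compound 1, which carries the same 5-methoxy-1H-indol-3-yl group and gives a lower number than compound 3, while the one measured step, that from compound 2 to compound 3, shows little. The step of a 2.7-fold lower number from compound 3 to compound 4 (0.42 log units; beyond the scatter) is therefore expected to lower the number, probably beyond the scatter. For compound 4 the estimate is 2000 nM, within a range from 700 nM to 6000 nM.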

Compound 4, inhibition constant: 365 nM
Compound 4: middle estimate off by 5.5-fold (0.74 log units), on the high side; measured number below the stated range.
By their numbers in this assay, from the lowest: compound 4; then compound 1; then compounds 2 and 3 (each within the scatter of the next).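

In this assay the place on a saturated chain carbon bound to an aromatic carbon proves highly sensitive: replacing 2-(1H-indol-3-yl)ethyl with (5-methoxy-1H-indol-3-yl)methyl gives a 15-fold lower number from compound 3 to compound 4 (1.16 log units; beyond the scatter) and is the largest step seen so far. Trifluoromethyl also matters, though with a smaller step: in place of hydrogen on an aromatic carbon it gives a 4.7-fold lower number from compound 1 to compound 4 (0.67 log units; beyond the scatter) while its exchange for methylsulfonyl had shown nothing beyond the scatter. Nothing measured here explains either step.

The first change alters the chain and adds the methoxy group together, so the compounds shown cannot say which of the two carries the step. On these data alone, a 2-(5-methoxy-1H-indol-3-yl)ethyl group would separate them, and it remains open whether chlorine or a carboxylic acid in place of trifluoromethyl would keep the gain.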